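Moving the Fluorine Around the Pendant Phenyl

This account rests on a few compounds, and the source may have more. Where it says the series, first, only, none or still open, it means among the compounds named here.

Compound 2 `O=S(=O)(c1cc(Cl)cc(Cl)c1)c1cnc2c(F)cccc2c1-c1ccccc1F` is one of three analogues that share a core carrying a sulfonyl aryl and a 2-fluorophenyl. In an ADME assay on microsomes from liver (Homo sapiens) for metabolic stability, tested at 2.5 uM (on this read-out lower numbers stand for slow clearance and higher numbers for fast clearance), compound 2 gives 0.44 mL/min, the second highest of the three numbers. Compound 3 `O=S(=O)(c1cccc(F)c1)c1cnc2c(F)cccc2c1-c1ccccc1F` gives 0.21 mL/min, and the step of a 2.1-fold lower number from compound 2 to compound 3 (0.32 log units; beyond the scatter) makes compound 3 the nearest neighbour of compound 2. Compound 1 `O=S(=O)(c1ccc(F)c(F)c1)c1cnc2c(F)cccc2c1-c1ccccc1F` gives 1.39 mL/min, the number furthest from compound 2; the step of a 3.2-fold lower number from compound 1 to compound 2 (0.50 log units; beyond the scatter) runs through the aryl on the sulfonyl sulfur, while the step of a 6.6-fold lower number from compound 1 to compound 3 (0.82 log units; beyond the scatter) replaces a fluoro with hydrogen on that same aryl.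

Compound 4 `O=S(=O)(c1cc(Cl)cc(Cl)c1)c1cnc2c(F)cccc2c1-c1ccc(F)cc1` differs from compound 2 in one place:
4-fluorophenyl in place of 2-fluorophenyl on an aromatic carbon
Every measured step concerns the aryl on the sulfonyl sulfur, whereas the 2-fluorophenyl on the shared core is identical in compounds 1, 2 and 3. Among the compounds with values here, no measured step therefore bears on this change, and the three numbers give no pointer in either direction. The step from compound 2 to compound 4 in this assay is accordingly expected to be no change at the digits printed from compound 2 to compound 4 (within the scatter), none beyond the scatter. Compound 4 is estimated at 0.44 mL/min, with a range from 0.18 mL/min to 1.1 mL/min.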

Compound 4, intrinsic clearance in a liver preparation (reported as CLH), per the amount of preparation that the assay uses: 1.01 mL/min
The estimate for compound 4 lay 2.3-fold (0.36 log units) below the measured number; the measured number falls inside the stated range.
By their numbers in this assay, from the lowest: compound 3; then compound 2; then compounds 4 and 1 (each within the scatter of the next).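

The fluorine on the phenyl attached to the shared core proves not to be a silent feature: with the 3,5-dichlorophenyl on the sulfonyl sulfur held fixed, 4-fluorophenyl in place of 2-fluorophenyl gives a 2.3-fold higher number from compound 2 to compound 4 (0.36 log units; beyond the scatter) in this assay and so moves the number toward faster clearance. Within the data shown here, this is the only measured step at this position, and it shows that a change joining the same atoms differently, with the heavy-atom count of the group unchanged, is enough to carry the number beyond the scatter, so the aryl on the sulfonyl sulfur is not the only place in these compounds where the read-out responds. Nothing measured here gives a reason for the step, and the move of the fluorine remains an observation without an explanation.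

On these data alone, the step has been read only with the 3,5-dichlorophenyl on the sulfonyl sulfur, so whether it would carry over to the 3-fluorophenyl of compound 3 or the 3,4-difluorophenyl of compound 1 stays open. Also open, as far as these compounds go, is where an unsubstituted phenyl, or a phenyl carrying a methoxy group or a nitrile, would stand at this position relative to compound 2 and compound 4 in this assay on the same scale.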